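The source may hold more compounds than are shown below. What is called first, only, known or untested is meant among the compounds shown, and "the series" means these compounds.

Compound 1 `O=C(Nc1ccc(-c2noc(-c3cccc(NS(=O)(=O)c4ccccc4)c3)n2)c(Cl)c1)c1cccnc1` — in a functional assay on MDA-MB-231 cells (Homo sapiens) for antiproliferative activity, read by MTT assay, with a stated time of 72 h (a lower number here means a stronger inhibitor, a higher number a weaker inhibitor), compound 1 gives > 10000 nM, which is a limit of the assay and not a number.
Compound 2 `O=C(Nc1ccc(-c2noc(-c3cccc(NS(=O)(=O)c4ccc(C(F)(F)F)cc4)c3)n2)c(Cl)c1)c1cccnc1` — in this assay compound 2 gives > 10000 nM, likewise a limit.
Compound 3 `CC(=O)Nc1ccc(S(=O)(=O)Nc2cccc(-c3nc(-c4ccc(NC(=O)c5cccnc5)cc4Cl)no3)c2)cc1` — in this assay compound 3 gives 2500 nM.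

Compound 3 is therefore the only one of the three with a measured number; the other two sit at the limit of > 10000 nM in this assay, at which 2 of the 3 values shown sit. The steps to it read an at least 4.0-fold lower number from compound 1 to compound 3 (0.60 log units; beyond the scatter) and an at least 4.0-fold lower number from compound 2 to compound 3 (0.60 log units; beyond the scatter), each a floor rather than an exact size, while the step that the two limits leave unreadable from compound 1 to compound 2 cannot be read at all.

Compound 4 `CC(=O)Nc1ccc(S(=O)(=O)Nc2cccc(-c3nc(-c4ccc(NC(=O)c5cccnc5)cc4Cl)no3)c2)cc1Cl` differs from compound 3 by chloro in place of hydrogen on an aromatic carbon. For the measured compounds named here, none of the measured steps adds a chloro; they exchange the group that the acetamido now occupies, so they say little about this change. Going by the values given here, with no step bearing directly on it, the expectation is that compound 4 stays within the scatter of compound 3, a step of no change at the digits printed from compound 3 to compound 4 (within the scatter). Compound 4 is thus estimated at 2500 nM in this assay, with a range from 800 nM to 8000 nM.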

Compound 4, half-maximal inhibitory concentration: > 10000 nM
Compound 4: no number, only a limit (the forecaster's own chance of this, stated with the estimate: 20%); middle value at least 4.0-fold (0.60 log units) away from the limit.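

In this assay, for the compounds shown here, chloro in place of hydrogen, ortho to an acetamido group, gives an at least 4.0-fold higher number from compound 3 to compound 4 (0.60 log units; beyond the scatter), so a single added atom on this ring is enough to lose the only measured number in the set. Compound 4 gives only a limit of the assay and not a number, which makes that step a floor, and the steps to compound 4 from compound 1 and from compound 2 cannot be read, with limits at both ends. The earlier steps shown here pointed to the acetamido group as what separated compound 3 from compound 1 and compound 2, but compound 4 keeps that group and still gives no number, so the acetamido alone is not sufficient and compound 3 stands alone: the limit of > 10000 nM in this assay, at which 3 of the 4 values shown sit.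

One pair cannot say whether this loss belongs to chloro itself or to any group placed ortho to the acetamido, and a fluoro or a methyl at the same place would tell these apart. Going by these compounds, it also remains open whether an amine in place of the acetamido would keep a measurable number, with or without the chloro.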